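Trimming the piperazine arm: what remains when it goes

The compounds below may be only part of what the source reports. "The series", "measured", "known", "first", "only" and "open" are said of these compounds alone.

Compound 1, `Cc1ccc(NC(=O)c2cccc(C(F)(F)F)c2)cc1-n1cc(-c2cnc3cccnn23)cn1`, gives in a functional assay on K562 cells (Homo sapiens) for antiproliferative activity, read by CCK-8 assay, with a stated time of 24 h (a lower number here means a stronger inhibitor, a higher number a weaker inhibitor), a value of < 2 nM.
Compound 2, `Cc1ccc(NC(=O)c2ccc(C(F)(F)F)cc2)cc1-n1cc(-c2cnc3cccnn23)cn1`, gives in this assay a value of 10500 nM.
Compound 3, `Cc1ccc(NC(=O)c2ccc(CN3CCN(C)CC3)cc2)cc1-n1cc(-c2cnc3cccnn23)cn1`, gives in this assay a value of < 2 nM.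

The value of compound 1 is a limit of the assay, not a number. The value of compound 3 is likewise only a limit. Compound 3 therefore stands with compound 1 at the strongest end of what this series shows, while compound 2 sits far away from both: an at least 5200-fold higher number from compound 1 to compound 2 (3.72 log units; beyond the scatter), and an at least 5200-fold lower number from compound 2 to compound 3 (3.72 log units; beyond the scatter). Going by these compounds, two of the three values rest at the same limit (the limit of < 2 nM in this assay, at which 2 of the 3 values shown sit), so the true gap between compound 1 and compound 3 and the true size of the step into compound 3 remain open.

Compound 4, `CCc1ccc(C(=O)Nc2ccc(C)c(-n3cc(-c4cnc5cccnn45)cn3)c2)cc1`, differs from compound 3 by methyl in place of 4-methylpiperazin-1-yl on a saturated chain carbon bound to an aromatic carbon. The step from compound 2 to compound 3 is the one that bears on this: adding the (4-methylpiperazin-1-yl)methyl group to a compound carrying trifluoromethyl at that aromatic carbon brought a very large gain. Compound 4 gives that group up and keeps only ethyl there, so a substantial loss is expected, though ethyl is not trifluoromethyl and compound 4 need not fall all the way to compound 2. The expected step is an at least 500-fold higher number from compound 3 to compound 4 (2.69 log units; beyond the scatter), and compound 4 is estimated at 1000 nM, with a range from 50 nM to 20000 nM.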

Compound 4, half-maximal inhibitory concentration: 7540 nM
Estimate against measurement, compound 4: 7.5-fold (0.88 log units) below; measured number inside the range.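

In this assay, the loss an at least 3700-fold higher number from compound 3 to compound 4 (3.57 log units; beyond the scatter) shows that what matters at this aromatic carbon is not simply a swap away from trifluoromethyl, since cutting (4-methylpiperazin-1-yl)methyl back to ethyl gives a 1.4-fold lower number from compound 2 to compound 4 (0.14 log units; within the scatter). Ethyl and trifluoromethyl therefore cannot be told apart here, and of compound 2, compound 3 and compound 4, only the compound carrying the 4-methylpiperazin-1-yl group reaches the strong end of the series. Compound 1 goes against any rule that this group is needed, as it carries no piperazine at all, and with 4-ethylphenyl in place of its 3-(trifluoromethyl)phenyl the result is an at least 3700-fold higher number from compound 1 to compound 4 (3.57 log units; beyond the scatter).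

Going by these compounds, it remains open whether a simpler amine such as dimethylamino, or a morpholine ring, on that saturated chain carbon would keep the activity, and whether 3-ethylphenyl would behave like 3-(trifluoromethyl)phenyl or like 4-ethylphenyl. The values of compound 1 and compound 3 are limits, so the two large steps give only a minimum size and the order of these two compounds cannot be read: the limit of < 2 nM in this assay, at which 2 of the 4 values shown sit.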